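The source may report more compounds than this note shows. Statements on the series, on what has been measured and on what is new or still open speak of the compounds shown alone.

Measured so far in an ADME assay on microsomes from liver (Mus musculus) for metabolic stability, with a stated time of 30 min, tested at 1 uM (on this read-out lower numbers stand for a less stable compound and higher numbers for a more stable compound), for three compounds:
- compound 1 `COc1cccc(S(=O)(=O)c2ccc(CN/C(=N\C#N)Nc3ccncc3)cc2)c1` gives 58%
- compound 2 `N#C/N=C(\NCc1ccc(S(=O)(=O)N2CC3CCC(C2)O3)cc1)Nc1ccncc1` gives 12%
- compound 3 `N#C/N=C(\NCc1ccc(S(=O)(=O)N2CC3CCC(C2)O3)cc1)Nc1cccnc1` gives 5.5%

Compound 2 sits low in this small set: it cannot be told apart from compound 3, and only compound 1 stands clearly away from it. Compound 4 `N#C/N=C(\NCc1ccc(S(=O)(=O)c2cccc(OC(F)(F)F)c2)cc1)Nc1ccncc1` has not yet been measured. Its difference from compound 2 is a group of 11 heavy atoms (7 carbon, 1 oxygen, 3 fluorine; one six-membered aromatic ring of carbon only) in place of a group of 8 heavy atoms (6 carbon, 1 nitrogen, 1 oxygen; one five-membered non-aromatic ring with 1 hetero atom, one six-membered non-aromatic ring with 2 hetero atoms), on a sulfonyl sulfur and the group that enters is 3-(trifluoromethoxy)phenyl.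

The measured step that bears most directly on this change is a number 46 percentage points lower from compound 1 to compound 2 (beyond the scatter) and it took place on the same sulfonyl sulfur. There, a group with one six-membered aromatic ring of carbon only gave way to the very group that compound 4 now gives up. Read backwards, that step points to a large rise. The other step of a number 6.5 percentage points lower from compound 2 to compound 3 (within the scatter) concerns pyridin-3-yl in place of pyridin-4-yl on an amine nitrogen, where compound 4 matches compound 2, so it carries little weight here. Within the data shown here, no measured compound yet carries the entering group, so the size stays uncertain.

The expected result in this assay is an estimated a number 43 percentage points higher from compound 2 to compound 4 (beyond the scatter) (a large rise). Compound 4 is expected to give 55% (estimated range 30% to 78%).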

Compound 4, percent of the compound remaining: 55%
The estimate for compound 4 equals the measured number at the digits printed, within the range that was stated.
By their numbers in this assay, from the lowest: compounds 3 and 2 (each within the scatter of the next); then compounds 4 and 1 (each within the scatter of the next).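

In this assay, the large step seen earlier now has a second example on the same sulfonyl sulfur: a number 43 percentage points higher from compound 2 to compound 4 (beyond the scatter), so a different aromatic group in place of the group with the two non-aromatic rings also goes with a much higher percentage remaining. The oxygen substituent on the aromatic ring makes no readable difference here: a number 3 percentage points lower from compound 1 to compound 4 (within the scatter), with trifluoromethyl in place of methyl on an oxygen on an aromatic ring, so compounds 1 and 4 cannot be told apart in this assay. Nothing measured here explains why the group on the sulfonyl sulfur matters so much or why these two oxygen substituents do not separate.

The compounds shown do not reveal whether the aromatic ring itself is what counts, since an unsubstituted phenyl or a simple open-chain group such as diethylamine on the sulfonyl sulfur would be needed to test that. They also leave open whether pyridin-3-yl in place of pyridin-4-yl on the amine nitrogen would matter as little with an aromatic group on the sulfonyl sulfur as the step between compounds 2 and 3 suggests.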